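From a pentyl chain to a hydroxy group

The source may hold more compounds than are shown below. What is called first, only, known or untested is meant among the compounds shown, and "the series" means these compounds.

Compound 1 `CCCCCCc1cn(C(c2ccccc2)c2cc3cc(Br)ccc3nc2OC)nn1` stands lowest of the three compounds measured in an ADME assay on PC-3 cells (Homo sapiens) for cytotoxicity, read by sulforhodamine B assay, with a stated time of 48 h, tested at 10 uM (on this read-out lower numbers stand for less inhibition and higher numbers for more inhibition at the one concentration tested (going by the name of the read-out)), where compound 1 gives 2.32%. Compound 2 `CCCc1cn(C(c2ccccc2)c2cc3cc(Br)ccc3nc2OC)nn1` gives 8.3% and compound 3 `COc1nc2ccc(Br)cc2cc1C(c1ccccc1)n1cc(CCO)nn1` gives 15.5%. The change in this assay is a number 6 percentage points higher from compound 1 to compound 2 (within the scatter), while it is a number 13.2 percentage points higher from compound 1 to compound 3 (beyond the scatter) and a number 7.2 percentage points higher from compound 2 to compound 3 (within the scatter).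

Compound 4 `COc1nc2ccc(Br)cc2cc1C(c1ccccc1)n1cc(CO)nn1` differs from compound 1 by hydroxy in place of pentyl on a saturated chain carbon bound to an aromatic carbon. Among the measured compounds shown here, the step most like it is the one from compound 1 to compound 3, a modest rise beyond the scatter, and the step from compound 2 to compound 3 points the same way but within the scatter. A rise of similar modest size is therefore expected, estimated as a number 12.7 percentage points higher from compound 1 to compound 4 (beyond the scatter). Compound 4 is expected to give about 15%, within a range from 3% to 28%.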

Compound 4, a percentage reported as inhibition, at one concentration (the size of the read-out at that concentration, not a potency): 4.65%
Beside the measured number, compound 4's estimate is 10.4 percentage points above it, within the range that was stated.
By their numbers in this assay, from the lowest: compounds 1, 4, 2 and 3 (each within the scatter of the next, the first and the last beyond it).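

Replacing pentyl with hydroxy on the saturated chain carbon bound to an aromatic carbon does not by itself raise the number in this assay (a number 2.3 percentage points higher from compound 1 to compound 4 (within the scatter)). The rise seen with compound 3 does not carry over to the shorter hydroxymethyl chain of compound 4 (a number 10.9 percentage points lower from compound 3 to compound 4 (beyond the scatter)), and compound 4 cannot be separated from the propyl-bearing compound 2 (a number 3.7 percentage points lower from compound 2 to compound 4 (within the scatter)). No evidence is available to explain this result. The compounds shown leave open how an amine, a carboxylic acid or a longer chain ending in hydroxy would read at this position.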